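Swapping methyl for fluoro on the sulfonyl ring

The compounds below may be only part of what the source reports. "The series", "measured", "known", "first", "only" and "open" are said of these compounds alone.

Of the compounds shown here, three sharing one core have been measured in a functional assay on PC-3 cells (Homo sapiens) for cytotoxicity, read by MTT assay, with a stated time of 72 h; a higher number here means a weaker inhibitor, a lower number a stronger inhibitor. Compound 1 `COc1cc(Nc2nc3ccccc3nc2S(=O)(=O)c2ccc(C)cc2)cc(OC)c1` gives 2940 nM, compound 2 `Cc1ccc(S(=O)(=O)c2nc3ccccc3nc2Nc2cccc(N)c2)cc1` gives 2000 nM and compound 3 `Cc1ccc(S(=O)(=O)c2nc3ccccc3nc2Nc2ccc(F)cc2)cc1` gives 13100 nM. Compound 2 sits level with compound 1 within the scatter (a 1.5-fold lower number from compound 1 to compound 2 (0.17 log units; within the scatter)) and well apart from compound 3 (a 6.6-fold higher number from compound 2 to compound 3 (0.82 log units; beyond the scatter)); compound 1 likewise stands apart from compound 3 (a 4.5-fold higher number from compound 1 to compound 3 (0.65 log units; beyond the scatter)). Compound 4 `Nc1cccc(Nc2nc3ccccc3nc2S(=O)(=O)c2ccc(F)cc2)c1` differs from compound 2 by fluoro in place of methyl on an aromatic carbon. All three measured steps instead changed the group on the nitrogen, so none of them bears directly on this change, and no step beyond the scatter is expected here. Compound 4 is therefore estimated to give 2000 nM, with a range from 800 nM to 5000 nM. The expected step is no change at the digits printed from compound 2 to compound 4 (within the scatter).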

Compound 4, half-maximal inhibitory concentration: 1980 nM
Beside the measured number, compound 4's estimate is 1.0-fold (0.00 log units) above it, within the range that was stated.
By their numbers in this assay, from the lowest: compounds 4, 2 and 1 (each within the scatter of the next); then compound 3.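

Every earlier step changed the group on the nitrogen, whereas this one changes 4-methylphenyl to 4-fluorophenyl on the other side of the shared core. In this assay that swap gives a 1.0-fold lower number from compound 2 to compound 4 (0.00 log units; within the scatter) and so leaves the number unmoved, showing that with 3-aminophenyl on the nitrogen, fluoro and methyl read alike at this position. Nothing available explains this match. On these data alone, whether a carboxylic acid or a longer chain such as propyl would read the same at this position remains open. So does whether fluoro and methyl still match with 3,5-dimethoxyphenyl or 4-fluorophenyl on the nitrogen.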